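Aryl tail swaps at the shared core: flat ring to piperidine

The source may hold more compounds than are shown below. What is called first, only, known or untested is meant among the compounds shown, and "the series" means these compounds.

Measured so far in a functional assay on HEK293 cells for agonist activity at Bombesin receptor subtype-3 (Mus musculus), read by luminescence and calcium flux, with a stated time of 10 min; a higher number here means that more compound is needed for the effect, a lower number that less compound is needed:
compound 1 `CCC(C)(C)Cc1c[nH]c(CCc2ccc(-n3cccn3)cc2)n1`: 113 nM
compound 2 `CCC(C)(C)Cc1c[nH]c(CCc2ccc(-n3ccnn3)cc2)n1`: 111 nM
compound 3 `CCC(C)(C)Cc1c[nH]c(CCc2ccc(-c3ccc(F)cn3)cc2)n1`: 105 nM

Compound 2 sits in the middle of these three numbers, but the three lie within the scatter of one another: a 1.0-fold lower number from compound 1 to compound 2 (0.01 log units; within the scatter), a 1.1-fold lower number from compound 1 to compound 3 (0.03 log units; within the scatter) and a 1.1-fold lower number from compound 2 to compound 3 (0.02 log units; within the scatter) are all small. Swapping one flat heteroaromatic ring for another on the aromatic carbon has so far left this assay unchanged.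

Compound 4 `CCC(C)(C)Cc1c[nH]c(CCc2ccc(N3CCCCC3)cc2)n1` is not yet measured. It differs from compound 2 as follows: piperidin-1-yl in place of 1H-1,2,3-triazol-1-yl on an aromatic carbon.

Going by the values given here, none of the measured steps covers this kind of change. They compare one aromatic ring against another, whereas here a six-membered non-aromatic ring with one hetero atom enters. Among the compounds with values here, their uniform outcome suggests the aromatic carbon tolerates varied substituents, which is the only guide available; it does not show what a non-aromatic ring does there. Beyond the scatter, no direction can be firmly read from the data, so the expectation is a modest step at most, with a wide range.

Compound 4 is therefore expected to give about 150 nM in this assay, within roughly 40 nM to 600 nM; the expected step is a 1.4-fold higher number from compound 2 to compound 4 (0.13 log units; within the scatter).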

Compound 4, half-maximal effective concentration: 133 nM
Beside the measured number, compound 4's estimate is 1.1-fold (0.05 log units) above it; the measured number falls inside the stated range.
By their numbers in this assay, from the lowest: compounds 3, 2, 1 and 4 (each within the scatter of the next).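

In this assay, the aromatic carbon para to a large group now carries a six-membered non-aromatic ring as well as flat aromatic rings, and piperidin-1-yl stays within the scatter of all three aromatic groups: against 1H-1,2,3-triazol-1-yl (a 1.2-fold higher number from compound 2 to compound 4 (0.08 log units; within the scatter)), against 1H-pyrazol-1-yl (a 1.2-fold higher number from compound 1 to compound 4 (0.07 log units; within the scatter)) and against 5-fluoropyridin-2-yl (a 1.3-fold higher number from compound 3 to compound 4 (0.10 log units; within the scatter)). The tolerance seen so far therefore extends past aromatic rings: compared with the 1H-1,2,3-triazol-1-yl group, piperidin-1-yl has a non-aromatic ring, 1 hetero atom and 1 hydrogen-bond acceptor, and the number still stays within the scatter. No supporting evidence bears on why this position accepts such different rings.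

As far as these compounds go, whether a carboxylic acid, a primary amine or a longer alkyl chain on this aromatic carbon would take the number beyond the scatter remains open. From the compounds shown here alone, all four compounds also share the rest of the structure, so it is equally open whether the same tolerance would hold with a different group in place of the shared core.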